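Swapping Acetyl for 1-Hydroxyethyl at a Cytotoxicity Limit

The source may report more compounds than this note shows. Statements on the series, on what has been measured and on what is new or still open speak of the compounds shown alone.

Compound 1 `COc1ccc(-c2nc3cc(C(C)=O)ccc3[nH]2)c(OC)c1`: 73000 nM
Compound 2 `COc1ccc(-c2nc3cc(C(C)=O)ccc3[nH]2)c(OC)c1OC`: > 100000 nM

In an ADME assay on MDBK cells (Bos taurus) for cytotoxicity, read by MTT assay, with a stated time of 96 h (on this read-out higher numbers stand for lower toxicity in this test and lower numbers for higher toxicity in this test), compound 1 gives 73000 nM. Compound 2 sits at the limit (the limit of > 100000 nM in this assay, at which 1 of the 2 values shown sits), so its reading of > 100000 nM is a limit of this assay, not a number. Going by the values given here, the only measured step, an at least 1.3-fold higher number from compound 1 to compound 2 (0.13 log units; that floor lies within the scatter), involves a methoxy and does not bear on the change to compound 3 `COc1ccc(-c2nc3cc(C(C)O)ccc3[nH]2)c(OC)c1OC`, which is 1-hydroxyethyl in place of acetyl on an aromatic carbon. Among the compounds with values here, with no measured step matching this change, no step beyond the scatter is expected in this assay. Compound 3 is therefore expected near 100000 nM, between 50000 nM and 200000 nM. The estimated step is a number no higher from compound 2 to compound 3 (the limit leaves the size open).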

Compound 3, half-maximal cytotoxic concentration: 60000 nM
Compound 3: middle estimate off by 1.7-fold (0.22 log units), on the high side; the range from low to high includes it.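

In this assay, going by these compounds alone, the first change at this position, 1-hydroxyethyl in place of acetyl on an aromatic carbon, gives an at least 1.6-fold lower number from compound 2 to compound 3 (0.22 log units; that floor lies within the scatter). The swap adds a hydrogen-bond donor and keeps the heavy-atom count, and compound 3 gives a true number. The full size of the step stays unknown because the reading for compound 2 is a limit, not a number: the limit of > 100000 nM in this assay, at which 1 of the 3 values shown sits.

On these data alone, whether an amine or a carboxylic acid here would move the reading beyond the scatter remains open. So does the effect of the same swap on the core of compound 1.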